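Urea and carbamate changes on a shared core

The compounds below may be only part of what the source reports. "The series", "measured", "known", "first", "only" and "open" are said of these compounds alone.

Measured so far:
compound 1 `CN(C)C(=O)Nc1cccc(-c2ccc(N(C)C)cc2)c1` gives an assay limit, < 5000 nM.
compound 2 `CCOC(=O)Nc1cccc(-c2ccc(N(C)C)cc2)c1` gives 3000 nM.
compound 3 `CN(C)C(=O)N(C)c1cccc(-c2ccc(N(C)C)cc2)c1` gives 70000 nM.

In an assay on COS-7 cells for inhibition of patatin-like phospholipase domain-containing protein 2 (Mus musculus) (a lower number here means a stronger inhibitor, a higher number a weaker inhibitor), compound 1 reaches only a limit of the assay, not a number. Compound 3 differs from compound 1 by methyl in place of hydrogen on an amide-type nitrogen; the step of an at least 14-fold higher number from compound 1 to compound 3 (1.14 log units; beyond the scatter) is large, and so is a 23-fold higher number from compound 2 to compound 3 (1.37 log units; beyond the scatter). Compound 2 differs from compound 1 by ethoxy in place of dimethylamino on a carbonyl carbon; the step that the limit leaves unreadable from compound 1 to compound 2 cannot be sized due to the limit of < 5000 nM in this assay, at which 1 of the 3 values shown sits.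

Compound 4 `CCOC(=O)N(C)c1cccc(-c2ccc(N(C)C)cc2)c1` is not yet measured. It differs from compound 3 by ethoxy in place of dimethylamino on a carbonyl carbon, the same change, at the same place, as from compound 1 to compound 2. Going by the values given here, the step from compound 3 to compound 4 is expected to be modest, a 1.4-fold lower number from compound 3 to compound 4 (0.15 log units; within the scatter), since the one comparable step, a step that the limit leaves unreadable from compound 1 to compound 2, gives no readable size and leaves no reason to expect a large shift. Compound 4 is expected near 50000 nM, plausibly between 15000 nM and 150000 nM.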

Compound 4, half-maximal inhibitory concentration: > 200000 nM
Compound 4 was reported as a limit (the forecaster's own chance of this, stated with the estimate: 25%); at least 4.0-fold (0.60 log units) between middle value and limit.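

In this assay compound 4 gives > 200000 nM, which is a limit of the assay and not a number. Methyl in place of hydrogen on an amide-type nitrogen gives an at least 66-fold higher number from compound 2 to compound 4 (1.82 log units; beyond the scatter), so the rise in the number carries from one core to the other in direction, but its size cannot be compared: the same change on two cores in this assay, an at least 14-fold higher number (1.14 log units; beyond the scatter) from compound 1 to compound 3 and an at least 66-fold higher number (1.82 log units; beyond the scatter) from compound 2 to compound 4; the limit leaves it open whether they differ Ethoxy in place of dimethylamino on a carbonyl carbon gives an at least 2.8-fold higher number from compound 3 to compound 4 (0.45 log units; beyond the scatter), and the two changes together give an at least 40-fold higher number from compound 1 to compound 4 (1.60 log units; beyond the scatter), but the step from compound 1 to compound 2 cannot be read, so whether the ethoxy change carries across cores remains unshown.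

The compounds shown leave open whether ethyl on the amide-type nitrogen behaves as methyl does. They also leave open whether methoxy on the carbonyl carbon behaves as ethoxy does.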